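Clearance notes: from compound 2 to compound 3

The source may report more compounds than this note shows. Statements on the series, on what has been measured and on what is new or still open speak of the compounds shown alone.

For the measured compounds named here, in an in vitro ADME assay on microsomes from liver (Mus musculus) for pharmacokinetics, read by LC-MS, with a stated time of 10 min, tested at 1 uM (on this read-out higher numbers stand for fast clearance and lower numbers for slow clearance), compound 2 `CN1C[C@H](C(=O)Nc2ccc(Cl)cn2)[C@@H](c2ccc(/C=C/C(=O)Nc3ccccc3N)cc2)C1` gives 31 mL/min/kg, the lower of the two numbers so far, while compound 1 `Cc1cccc(NC(=O)[C@H]2CN(C)C[C@@H]2c2ccc(/C=C/C(=O)Nc3ccccc3N)cc2)c1` gives 74 mL/min/kg. The next structure, compound 3 `CN1C[C@H](C(=O)N2CCCCC2)[C@@H](c2ccc(/C=C/C(=O)Nc3ccccc3N)cc2)C1`, differs from compound 2 as follows: piperidin-1-yl in place of (5-chloropyridin-2-yl)amino on a carbonyl carbon. This reads as (5-chloropyridin-2-yl)carbamoyl to (piperidin-1-yl)carbonyl.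

Going by the values given here, only one measured step bears on this change: a 2.4-fold lower number from compound 1 to compound 2 (0.38 log units; beyond the scatter). It is modest but beyond the scatter, and it came with 5-chloropyridin-2-yl in place of 3-methylphenyl on an amide-type nitrogen. Among the compounds with values here, no measured compound carries piperidin-1-yl, so the support is weak. Within the data shown here, a modest move towards a higher number is expected, since compound 2 holds the lower of only two values. The expected step is a 1.8-fold higher number from compound 2 to compound 3 (0.25 log units; within the scatter). For compound 3 the estimated clearance is 55 mL/min/kg, within an expected range of 25 mL/min/kg to 110 mL/min/kg.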

Compound 3, clearance: 42 mL/min/kg
Estimate against measurement, compound 3: 1.3-fold (0.12 log units) above; the measured number falls inside the stated range.
By their numbers in this assay, from the lowest: compounds 2, 3 and 1 (each within the scatter of the next, the first and the last beyond it).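

In this assay, piperidin-1-yl on the carbonyl carbon gives a 1.4-fold higher number from compound 2 to compound 3 (0.13 log units; within the scatter) and a 1.8-fold lower number from compound 1 to compound 3 (0.25 log units; within the scatter), so compound 3 lies within the scatter of both earlier compounds. The earlier pair held only aromatic rings on an amide-type nitrogen with a hydrogen-bond donor, whereas this position now also carries a six-membered non-aromatic ring with no hydrogen-bond donor, and the clearance stays within the span set by compound 1 and compound 2. Nothing measured here accounts for these steps.

As far as these compounds go, the aromatic ring and the amide hydrogen leave together in both steps, so their separate contributions stay open. Also open, from the compounds shown here alone, is how morpholin-4-yl or dimethylamino on the same carbonyl carbon would read against the piperidin-1-yl of compound 3.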